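This account rests on a few compounds, and the source may have more. Where it says the series, first, only, none or still open, it means among the compounds named here.

Measured in an ADME assay on microsomes from liver (Homo sapiens) for metabolic stability, read by LC-MS, using NADPH, with stated times of 5 min and 30 min, tested at 1 uM; a higher number here means faster removal of the compound, a lower number slower removal:
- compound 1 `Cc1nccn1-c1cnc(NCc2c(F)ccc3c2CCO3)c2cn[nH]c(=O)c12`: 8 mL.min-1.g-1
- compound 2 `O=C1CCCN1c1cnc(NCc2c(F)ccc3c2CCO3)c2cn[nH]c(=O)c12`: 23 mL.min-1.g-1

Of these two, compound 2 has the highest number, so it is removed faster. Compound 3 `Cc1ncc(-c2cnc(NCc3c(F)ccc4c3CCO4)c3cn[nH]c(=O)c23)n1C` is not yet measured. It carries 1,2-dimethyl-1H-imidazol-5-yl in place of 2-oxopyrrolidin-1-yl on an aromatic carbon. Going by the values given here, one measured step bears on this, a 2.9-fold higher number from compound 1 to compound 2 (0.46 log units; beyond the scatter), which is modest and exchanged 2-methyl-1H-imidazol-1-yl for the same 2-oxopyrrolidin-1-yl. Compound 3 also carries an imidazole, like compound 1 at 8 mL.min-1.g-1, though attached differently, so that step should roughly reverse. The expected change is a lower number, a 2.1-fold lower number from compound 2 to compound 3 (0.32 log units; beyond the scatter). For compound 3 the estimate is 11 mL.min-1.g-1, with an expected range of 5 mL.min-1.g-1 to 24 mL.min-1.g-1.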

Compound 3, intrinsic clearance in microsomes: 10 mL.min-1.g-1
Estimate against measurement, compound 3: 1.1-fold (0.04 log units) above; the range from low to high includes it.
By their numbers in this assay, from the lowest: compounds 1 and 3 (each within the scatter of the next); then compound 2.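

In this assay, this position gives a 2.3-fold lower number from compound 2 to compound 3 (0.36 log units; beyond the scatter), so the low number of compound 1 is not limited to one way of attaching an imidazole. Exchanging 2-methyl-1H-imidazol-1-yl for 1,2-dimethyl-1H-imidazol-5-yl gives a 1.3-fold higher number from compound 1 to compound 3 (0.10 log units; within the scatter), so these two imidazoles cannot be told apart here. Nothing shown explains the gap between these imidazoles and 2-oxopyrrolidin-1-yl. Going by these compounds, it remains open how a phenyl ring or an open-chain amide would behave at this position, and whether the methyl groups on the imidazoles matter.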